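The source may report more compounds than this note shows. Statements on the series, on what has been measured and on what is new or still open speak of the compounds shown alone.

Measured in an assay on isolated protein for inhibition of Polyunsaturated fatty acid 5-lipoxygenase (Homo sapiens), read by HPLC, with a stated time of 15 min, in the presence of a further agent that is not named here; a higher number here means a weaker inhibitor, a lower number a stronger inhibitor:
compound 1 `CCCCC(Sc1ccc(OCCCOc2ccc(C)cc2)cc1)C(=O)O`: 5200 nM
compound 2 `CCCCC(Sc1ccc(OCCCOc2cccc(C)c2)cc1)C(=O)O`: 4800 nM
compound 3 `CCCCC(Sc1ccc(OCCCOc2ccc(Cl)cc2OC)cc1)C(=O)O`: a limit only, > 10000 nM

Compound 1 stands highest of the two numbers, with compound 2 nearest (a 1.1-fold lower number from compound 1 to compound 2 (0.03 log units; within the scatter)). Compound 3 sits at the limit (the limit of > 10000 nM in this assay, at which 1 of the 3 values shown sits). The step to it reads an at least 1.9-fold higher number from compound 1 to compound 3 (0.28 log units; that floor lies within the scatter) and an at least 2.0-fold higher number from compound 2 to compound 3 (0.31 log units; beyond the scatter).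

Compound 4 is `CCCCC(Sc1ccc(OCCCOc2ccc(-c3ccccc3)cc2)cc1)C(=O)O`; against compound 1 the change is phenyl in place of methyl on an aromatic carbon. Going by the values given here, no measured step touches this position in the same way: one exchanges 4-methylphenyl for 3-methylphenyl, the others replace the methylphenyl with 4-chloro-2-methoxyphenyl, and none of them moves the number far from compound 1. Compound 4 is therefore expected near 5000 nM, from 2000 nM to 12000 nM. The expected step is a 1.0-fold lower number from compound 1 to compound 4 (0.02 log units; within the scatter), within the scatter.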

Compound 4, half-maximal inhibitory concentration: 900 nM
The estimate for compound 4 lay 5.6-fold (0.74 log units) above the measured number, and the stated range ends above it.
By their numbers in this assay, from the lowest: compound 4; then compounds 2 and 1 (each within the scatter of the next). At a limit, above all of these: compound 3.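

Going by these compounds alone, on the aromatic carbon para to a large group, phenyl in place of methyl gives a 5.8-fold lower number from compound 1 to compound 4 (0.76 log units; beyond the scatter) in this assay as the first lower number that lies beyond the scatter. The position therefore responds to this change, whereas moving the methyl from 4-methylphenyl to 3-methylphenyl left the number within the scatter. No measured property shown here bears on this step.

From the compounds shown here alone, it remains open whether the added ring must be aromatic; a cyclohexyl or tert-butyl group on this carbon would separate aromatic ring from size. Also open, going by these compounds, is how an amine on the added phenyl would move the number.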